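The source may report more compounds than this note shows. Statements on the series, on what has been measured and on what is new or still open speak of the compounds shown alone.

Compound 3, `Cc1ccc(OCC(=O)N(Cc2cccs2)c2c(C)n[nH]c2C)cc1`, gives 0.3 nM in an assay on HEK293 cells for agonist activity at transient receptor potential cation channel subfamily M member 8 (Homo sapiens), read by fluorescence and calcium flux, with a stated time of 15 min (on this read-out higher numbers stand for an effect only at larger amounts of compound and lower numbers for an effect already at smaller amounts), the lowest of the three measured numbers. Compound 2, `Cc1ccc(OCC(=O)N(Cc2cccs2)c2ccnn2C)cc1`, gives 422 nM in this assay, and compound 1, `Cc1ccc(OCC(=O)N(Cc2cccs2)C2CCCCC2)cc1`, gives 40000 nM in this assay. The steps toward compound 3 were both large: a 130000-fold lower number from compound 1 to compound 3 (5.12 log units; beyond the scatter) and a 1400-fold lower number from compound 2 to compound 3 (3.15 log units; beyond the scatter), and a 95-fold lower number from compound 1 to compound 2 (1.98 log units; beyond the scatter) was large as well. Compound 4, `Cc1ccc(OCC(=O)N(Cc2cccs2)C2CC2)cc1`, differs from compound 3 in one place: cyclopropyl in place of 3,5-dimethyl-1H-pyrazol-4-yl on an amide-type nitrogen. Cyclohexyl and cyclopropyl are both saturated rings of carbon only, each with no hydrogen-bond donor or acceptor. The step of a 130000-fold lower number from compound 1 to compound 3 (5.12 log units; beyond the scatter) therefore bears most directly on this change, and read in reverse it points toward a much higher number for compound 4, though the smaller ring leaves some room for a difference from compound 1. The expected step is a 50000-fold higher number from compound 3 to compound 4 (4.70 log units; beyond the scatter). For compound 4 the estimate in this assay is 15000 nM, with a range from 1500 nM to 100000 nM.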

Compound 4, half-maximal effective concentration: 8 nM
Compound 4: middle estimate off by 1900-fold (3.27 log units), on the high side, and the stated range ends above it.
By their numbers in this assay, from the lowest: compound 3; then compound 4; then compound 2; then compound 1.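

The position on the amide-type nitrogen turns out not to need a pyrazole for a low number in this assay: cyclopropyl, a ring of carbon only, gives a 53-fold lower number from compound 2 to compound 4 (1.72 log units; beyond the scatter), so it outperforms 1-methyl-1H-pyrazol-5-yl, although 3,5-dimethyl-1H-pyrazol-4-yl remains better, with a 27-fold higher number from compound 3 to compound 4 (1.43 log units; beyond the scatter). The two carbon-only rings also differ widely, with a 5000-fold lower number from compound 1 to compound 4 (3.70 log units; beyond the scatter), so the absence of hetero atoms does not by itself set the number at this position, and the size of the ring or something tied to it counts. No measurement offered here explains these differences.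

The compounds shown leave open whether the number climbs steadily from cyclopropyl to cyclohexyl, as cyclobutyl and cyclopentyl would tell, and whether a ring is needed at all, as isopropyl would tell. They also leave open what the ring nitrogen hydrogen of 3,5-dimethyl-1H-pyrazol-4-yl contributes, which 1,3,5-trimethyl-1H-pyrazol-4-yl would address.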